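Swapping the Aromatic Ring Again: What Compound 4 Should Show

The source may hold more compounds than are shown below. What is called first, only, known or untested is meant among the compounds shown, and "the series" means these compounds.

In an in vitro functional assay on HEK285-7 cells for antagonist activity at prostaglandin D2 receptor 2 (Homo sapiens), read by BRET and beta-arrestin recruitment (on this read-out higher numbers stand for larger maximal responses and lower numbers for smaller maximal responses), compound 3 `O=C(O)Cc1sc(C(c2ccc(F)cc2)c2ccc(F)cc2)nc1-c1cccc(F)c1` gives 80%. Compound 1 `O=C(O)Cc1sc(C(c2ccc(F)cc2)c2ccc(F)cc2)nc1-c1ccnc(N2CCC2)c1` gives 80% and compound 2 `O=C(O)Cc1sc(C(c2ccc(F)cc2)c2ccc(F)cc2)nc1-c1ccncc1` gives 80%, so compound 3 stands level with both at the digits shown. Compound 4 `O=C(O)Cc1sc(C(c2ccc(F)cc2)c2ccc(F)cc2)nc1-c1cc(F)nc(F)c1` differs from compound 3 in one place: 2,6-difluoropyridin-4-yl in place of 3-fluorophenyl on an aromatic carbon. All three measured steps swap this same aromatic group, and none moved the maximal response beyond the scatter: no change at the digits printed from compound 1 to compound 2 (within the scatter), no change at the digits printed from compound 1 to compound 3 (within the scatter) and no change at the digits printed from compound 2 to compound 3 (within the scatter). The step most like the present one, from compound 2 to compound 3, exchanges pyridin-4-yl and 3-fluorophenyl and stayed flat. Compound 4 is therefore expected to show no change at the digits printed from compound 3 to compound 4 (within the scatter), that is nothing beyond the scatter. The estimate for compound 4 is 80%, ranging from 70% to 90%.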

Compound 4, largest response reached (reported as efficacy), in percent of the reference or control that the assay uses: 80%
Compound 4: middle estimate and measured number agree at the digits printed; the range from low to high includes it.
By their numbers in this assay, from the lowest: compounds 1, 2, 3 and 4 (each within the scatter of the next).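

In this assay the new 2,6-difluoropyridin-4-yl group, with its ring nitrogen and two fluorines, gives no change at the digits printed from compound 3 to compound 4 (within the scatter) and also no change at the digits printed from compound 2 to compound 4 (within the scatter) and no change at the digits printed from compound 1 to compound 4 (within the scatter) in this comparison set. This place on the shared core has now held four different aromatic groups with maximal responses that all lie within the scatter. Nothing measured here explains this flat result.

Every group shown at this place is aromatic, so the effect of a saturated ring such as cyclohexyl, or of a short chain ending in an amine, remains open.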